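Dropping the carbamoyl arm: what compound 3 might give

The compounds below may be only part of what the source reports. "The series", "measured", "known", "first", "only" and "open" are said of these compounds alone.

Measured compounds:
Compound 1 `CNc1nc(C)c(C(=O)N/N=C/c2ccc(C(F)(F)F)cc2)s1` gives > 100 ug/mL in a functional assay on HeLa cells (Homo sapiens) for inhibition, read by MTT assay, with a stated time of 72 h (on this read-out higher numbers stand for weaker inhibition and lower numbers for stronger inhibition), which is a limit of the assay and not a number.
Compound 2 `CN(C(=O)NC(=O)c1ccccc1F)c1nc(C(F)(F)F)c(C(=O)N/N=C/c2ccc(C(F)(F)F)cc2)s1` gives 3.97 ug/mL in this assay.

In this assay compound 2 holds the only number shown. The other result, that of compound 1, is a limit of the assay (the limit of > 100 ug/mL in this assay, at which 1 of the 2 values shown sits). Compound 3 `CNc1nc(C(F)(F)F)c(C(=O)N/N=C/c2ccc(C(F)(F)F)cc2)s1` is the compound still to be measured; it differs from compound 2 by hydrogen in place of ((2-fluorophenyl)carbonyl)carbamoyl on a nitrogen on an aromatic ring. Going by the values given here, no pair of measured compounds differs in this one place alone, so no measured step size exists for this change. Compound 1, which also carries a hydrogen on that nitrogen, sits at the limit. Among the compounds with values here, compound 2, carrying the larger group, is the one with a measured number. On that showing, the step from compound 2 to compound 3 is expected to weaken inhibition, a 15-fold higher number from compound 2 to compound 3 (1.18 log units; beyond the scatter). Compound 3 is therefore estimated at 60 ug/mL, with a likely range from 15 ug/mL to 200 ug/mL, and a real chance that only a limit is reported.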

Compound 3, half-maximal inhibitory concentration: > 100 ug/mL
Compound 3: only a limit was reported (the forecaster's own chance of this, stated with the estimate: 45%); middle value at least 1.6-fold (0.22 log units) from the limit.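

In this assay, going by these compounds alone, compound 2 and compound 3 differ in one place only, and hydrogen in place of ((2-fluorophenyl)carbonyl)carbamoyl on the nitrogen on an aromatic ring gives an at least 25-fold higher number from compound 2 to compound 3 (1.40 log units; beyond the scatter), the first readable step at this position. With trifluoromethyl present in both compounds, the measured number of compound 2 is lost when this group leaves, so trifluoromethyl on the aromatic carbon does not by itself bring the hydrogen-bearing compound to a measured number in this assay. The result for compound 3 is a limit of the assay and not a number, so the step sets only a lower bound on the size of this change: the limit of > 100 ug/mL in this assay, at which 2 of the 3 values shown sit.

From the compounds shown here alone, the step between compound 1 and compound 3, trifluoromethyl in place of methyl on an aromatic carbon, cannot be read from two limits, and the effect of that change on its own stays open. Also open, going by these compounds, is how much of the departed group is needed on that nitrogen, for instance whether an acetyl group or a plain carbamoyl would give a result nearer to compound 2 or to compound 3.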